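Cyanoguanidine aryl swap on the shared benzopyran core

The source may report more compounds than this note shows. Statements on the series, on what has been measured and on what is new or still open speak of the compounds shown alone.

Measured compounds so far:
- compound 1 `CC1(C)Oc2ccc(C#N)cc2[C@@H](n2c(O)nc3ccccc32)[C@@H]1O`: 41000 nM
- compound 2 `CC1(C)Oc2ccc(C#N)cc2[C@@H](n2cc(C#N)c3ccccc32)[C@@H]1O`: 2200 nM
- compound 3 `CC1(C)Oc2ccc(C#N)cc2[C@@H](/N=C(\NC#N)Nc2ccc([N+](=O)[O-])cc2)[C@@H]1O`: 300 nM

All three values come from a functional assay (aorta) with Rattus norvegicus as the target; on this read-out higher numbers stand for weaker inhibition and lower numbers for stronger inhibition. Compound 3 gives 300 nM, the lowest number of the three and therefore the strongest inhibition on this read-out. Compound 2, with 2200 nM, lies well beyond the scatter from compound 3, and compound 1, with 41000 nM, lies further still. Going by the values given here, no pair among the measured compounds differs in a single place, so the three numbers are taken as they stand, without any step computed between them.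

The next compound is compound 4 `CC1(C)Oc2ccc(C#N)cc2[C@@H](/N=C(\NC#N)Nc2ccc(Cl)c(F)c2)[C@@H]1O`. It differs from compound 3 in one place: 4-chloro-3-fluorophenyl in place of 4-nitrophenyl on an amine nitrogen. The group on the amine nitrogen changes from a ring carrying a nitro substituent to one carrying chlorine and fluorine; the rest of the molecule is unchanged.

Nothing measured here speaks to the effect of this particular exchange, so the expectation rests on compound 3 alone. A step from compound 3 to compound 4 of about a 1.3-fold higher number from compound 3 to compound 4 (0.12 log units; within the scatter) is expected, within or close to the scatter. Compound 4 is estimated at 400 nM, with a range from 100 nM to 1600 nM.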

Compound 4, half-maximal inhibitory concentration: 1660 nM
Compound 4: middle estimate off by 4.2-fold (0.62 log units), on the low side; the measured number lies above the stated range.
By their numbers in this assay, from the lowest: compound 3; then compounds 4 and 2 (each within the scatter of the next); then compound 1.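

In this assay, going by these compounds alone, exchanging 4-nitrophenyl for 4-chloro-3-fluorophenyl on the amine nitrogen gives a 5.5-fold higher number from compound 3 to compound 4 (0.74 log units; beyond the scatter), the first single-place comparison. It shows that the number responds to the aryl group at this position while the rest of the molecule stays unchanged, and that of these two groups, 4-nitrophenyl carries the lower number and so the stronger inhibition. The exchange removes the nitro group and brings in chlorine and fluorine together, so this one step cannot be divided among them, and no measurement at hand accounts for it.

Still open, from the compounds shown here alone, is how 4-chlorophenyl and 3-fluorophenyl, each carrying only one of the two halogens, would stand against compound 3 and compound 4 in this assay. Also open, going by these compounds, is whether the nitro group itself matters or whether another ring substituent, as in 4-cyanophenyl, or a saturated group such as cyclohexyl on the same nitrogen would give a number close to that of compound 3.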